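The source may hold more compounds than are shown below. What is called first, only, known or untested is meant among the compounds shown, and "the series" means these compounds.

Three compounds share one core and differ only in the group set on an aromatic carbon of the fused ring system. Compound 1 `CCCCN(c1nc2c(C(=O)O)cccc2o1)[C@H](C)c1ccc(-c2ccccc2-c2nnn[nH]2)cc1` carries a carboxy group, compound 2 `CCCCN(c1nc2c(-c3nccn3C)cccc2o1)[C@H](C)c1ccc(-c2ccccc2-c2nnn[nH]2)cc1` a 1-methyl-1H-imidazol-2-yl group, and compound 3 `CCCCN(c1nc2c(NC(C)=O)cccc2o1)[C@H](C)c1ccc(-c2ccccc2-c2nnn[nH]2)cc1` an acetamido group. In an ADME assay on the whole organism (Macaca fascicularis) for pharmacokinetics, read by LC-MS, using cassette dosing, at a dose of 1 mg/kg by the oral route (on this read-out higher numbers stand for higher exposure at the dose given and lower numbers for lower exposure), compound 1 gives 238 nM, compound 2 gives 154 nM, and compound 3 gives 26.6 nM. Compound 3 stands lowest of the three: an 8.9-fold lower number from compound 1 to compound 3 (0.95 log units; beyond the scatter) and a 5.8-fold lower number from compound 2 to compound 3 (0.76 log units; beyond the scatter) are both beyond the scatter, whereas a 1.5-fold lower number from compound 1 to compound 2 (0.19 log units; within the scatter) stays within it.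

Compound 4 `CCCCN(c1nc2c(C(=O)N(C)C)cccc2o1)[C@H](C)c1ccc(-c2ccccc2-c2nnn[nH]2)cc1` has not yet been measured. The change is dimethylcarbamoyl in place of acetamido on an aromatic carbon. Within the data shown here, no measured step makes exactly this exchange, so the expectation leans on the nearest one, an 8.9-fold lower number from compound 1 to compound 3 (0.95 log units; beyond the scatter), in which a carboxy group, like dimethylcarbamoyl a group without a hydrogen-bond donor, occupied the same place and went with the higher number. From the compounds shown here alone, because of an 8.9-fold lower number from compound 1 to compound 3 (0.95 log units; beyond the scatter) the number for compound 4 is expected to move part of the way back up, though with wide uncertainty since the exchange itself is untested. The step expected in this assay is a 3.4-fold higher number from compound 3 to compound 4 (0.53 log units; beyond the scatter), a modest rise. Compound 4 is therefore estimated at 90 nM, within a range from 30 nM to 300 nM.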

Compound 4, maximal plasma concentration: 54 nM
For compound 4 the middle estimate is 1.7-fold (0.22 log units) above the measured one; the range from low to high includes it.
By their numbers in this assay, from the lowest: compound 3; then compound 4; then compounds 2 and 1 (each within the scatter of the next).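

In this assay the place on the aromatic carbon responds to more than the atoms of an amide: acetamido and dimethylcarbamoyl each hold a carbonyl and a nitrogen and carry no net charge, yet exchanging the first for the second gives a 2.0-fold higher number from compound 3 to compound 4 (0.31 log units; beyond the scatter) and leaves compound 4 clear of compound 3. The rise does not recover the higher numbers, with a 2.9-fold lower number from compound 2 to compound 4 (0.46 log units; beyond the scatter) against the imidazole compound and a 4.4-fold lower number from compound 1 to compound 4 (0.64 log units; beyond the scatter) when dimethylamino replaces the hydroxy of the carboxy group, so compound 4 takes a middle rank of its own, above compound 3 and below compounds 1 and 2. No measurement here explains any of these steps.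

The exchange alters several things together, since acetamido has 1 hydrogen-bond donor and 4 heavy atoms while dimethylcarbamoyl has 0 hydrogen-bond donors and 5 heavy atoms, and these compounds cannot separate those differences. A primary carboxamide, an N-methyl carboxamide or a methyl ester at the same place would help show which feature tracks with the maximal plasma concentration.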